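This account rests on a few compounds, and the source may have more. Where it says the series, first, only, none or still open, it means among the compounds named here.

Three compounds have been measured in a physicochemical assay for solubility, at pH 7; on this read-out higher numbers stand for higher solubility and lower numbers for lower solubility:

Compound 1 `CC(=O)N1CCN(C(=O)N2Cc3c(NC(=O)c4ccc(F)cc4)n[nH]c3C2(C)C)CC1`: > 225000 nM
Compound 2 `CN(C)CC(=O)Nc1n[nH]c2c1CN(C(=O)C(C)(C)C)C2(C)C`: > 225000 nM
Compound 3 `CC1(C)c2[nH]nc(NC(=O)c3ccc(F)cc3)c2CN1C(=O)N1CCN(c2ccccc2)CC1`: 55000 nM

Compound 1 stands at > 225000 nM, which is a limit of the assay and not a number. Compound 2 likewise gives only a limit, > 225000 nM. Together they make up (the limit of > 225000 nM in this assay, at which 2 of the 3 values shown sit). Among the compounds with values here, compound 3 is the only one with a true number, 55000 nM.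

The next compound to be examined is compound 4 `CCN1CCC(C(=O)N2Cc3c(NC(=O)c4ccc(F)cc4)n[nH]c3C2(C)C)CC1`. It carries 1-ethylpiperidin-4-yl in place of 4-acetylpiperazin-1-yl on a carbonyl carbon.

Within the data shown here, only one measured step bears on this change, and it bears only in part. That step is an at least 4.0-fold lower number from compound 1 to compound 3 (0.61 log units; beyond the scatter), where phenyl takes the place of acetyl on an amine nitrogen in a ring. Going by these compounds, compound 4 also loses the acetyl group, but it gains no phenyl, so that step is a weak guide and its full size is unknown. No shift beyond the scatter is therefore expected in this assay, although a modest fall remains possible. The expected step is an at least 1.1-fold lower number from compound 1 to compound 4 (0.05 log units; that floor lies within the scatter). The estimated value for compound 4 is 200000 nM, with an expected range from 70000 nM to 450000 nM.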

Compound 4, solubility: > 225000 nM
Compound 4 gave a limit, no number (the forecaster's own chance of this, stated with the estimate: 55%); at least 1.1-fold (0.05 log units) between middle value and limit.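

Compound 1 and compound 4 each give only a limit of the assay in this assay, not a number, so no step can be read between them: the limit of > 225000 nM in this assay, at which 3 of the 4 values shown sit. The compounds shown leave open whether 1-ethylpiperidin-4-yl in place of 4-acetylpiperazin-1-yl on a carbonyl carbon changes the read-out at all, and in which direction.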